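Truncating the urea tail of the shared core

This account rests on a few compounds, and the source may have more. Where it says the series, first, only, none or still open, it means among the compounds named here.

Compound 1 `COc1ncc(-c2ccc3nc(NC(=O)NCCN4CCCC4)nn3c2)cc1NS(=O)(=O)c1ccc(F)cc1` is tested in a functional assay on U-87MG ATCC cells for cytotoxicity against U-87 MG (Homo sapiens), read by MTT assay, with a stated time of 72 h (on this read-out lower numbers stand for stronger inhibition and higher numbers for weaker inhibition), and gives 1120 nM. Among the two compounds measured so far it carries the higher number, with its nearest neighbour compound 2 `COc1ncc(-c2ccc3nc(NC(=O)NCC(=O)N4CCCC4)nn3c2)cc1NS(=O)(=O)c1ccc(F)cc1` giving 1000 nM. Among the measured compounds shown here, the one step that connects them, a 1.1-fold lower number from compound 1 to compound 2 (0.05 log units; within the scatter), shows that exchanging the end of the urea tail left the read-out essentially unchanged. Compound 3 `CNC(=O)Nc1nc2ccc(-c3cnc(OC)c(NS(=O)(=O)c4ccc(F)cc4)c3)cn2n1` has not been measured; it differs from compound 1 by hydrogen in place of (pyrrolidin-1-yl)methyl on a saturated chain carbon bound to an amide-type nitrogen. For the measured compounds named here, no measured step removes the ring altogether, so the step from compound 1 to compound 2 bears on it only as a sign that this part of the tail tolerated one exchange without a shift. On that basis the expected step is a 1.3-fold higher number from compound 1 to compound 3 (0.13 log units; within the scatter), with direction uncertain. Compound 3 is therefore estimated at 1500 nM, with a range of 500 nM to 5000 nM.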

Compound 3, half-maximal inhibitory concentration: 640 nM
Compound 3: the middle estimate sits 2.3-fold (0.37 log units) above what was measured; the measured number falls inside the stated range.
By their numbers in this assay, from the lowest: compounds 3, 2 and 1 (each within the scatter of the next).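

Removing the whole (pyrrolidin-1-yl)methyl group, which leaves a plain methyl on the urea, does not move the read-out in this assay beyond the scatter (a 1.8-fold lower number from compound 1 to compound 3 (0.24 log units; within the scatter)). The same holds for the (pyrrolidin-1-yl)carbonyl group (a 1.6-fold lower number from compound 2 to compound 3 (0.19 log units; within the scatter)). Where compounds 1 and 2 showed only that one ring-bearing tail end could stand in for another, compound 3 shows that neither the ring nor the rest of the tail beyond the methyl is needed to keep the number at this level; no measurement offered here accounts for this.

Still open, on these data alone, is whether a carboxylic acid, a primary amine or a longer unbranched alkyl chain on this saturated chain carbon would shift the number beyond the scatter. Also open, as far as these compounds go, is whether the methyl itself can be replaced by hydrogen without such a shift.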